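The compounds below may be only part of what the source reports. "The series", "measured", "known", "first", "only" and "open" are said of these compounds alone.

In a functional assay on MT4 cells (Homo sapiens) for cytotoxicity (on this read-out higher numbers stand for weaker inhibition and lower numbers for stronger inhibition), compound 1 `Cc1ccc(Sc2cccc(N)c2C#N)cc1` gives > 200000 nM, which is a limit of the assay and not an exact number. Compound 2 `COc1ccc(S(=O)(=O)c2cccc(N)c2C#N)cc1` gives > 200000 nM, which is also a limit. That places compound 2 at the limit of > 200000 nM in this assay, at which 2 of the 2 values shown sit.

Compound 3 `N#Cc1c(N)cccc1S(=O)(=O)c1ccc(Br)cc1` differs from compound 2 in one place, with bromo in place of methoxy on an aromatic carbon, para to a large group: bromo in place of methoxy on an aromatic carbon. Among the compounds with values here, no measured step shows what this swap does, so the expected size of a number no higher from compound 2 to compound 3 (the limit leaves the size open) is nothing beyond the scatter, in either direction. The estimate in this assay for compound 3 is 200000 nM, expected to fall between 80000 nM and 300000 nM.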

Compound 3, half-maximal inhibitory concentration: > 200000 nM
Compound 3 gave a limit, no number (the forecaster's own chance of this, stated with the estimate: 65%); the middle value sits exactly at the limit.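

Compound 2 and compound 3 both give only a limit, so the step between them cannot be read: the limit of > 200000 nM in this assay, at which 3 of the 3 values shown sit.

The compounds shown leave open whether bromo and methoxy differ at all in this assay, and at what concentration any of them would reach half-maximal inhibition.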